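A few compounds are considered here, and "the series" means these few. Any claim that something is new, unique, unknown or untested is made for them only; others in the source may bear on it.

Measured compounds:
compound 1 `Cc1cc(C(N)=O)nn1Cc1cc(Cl)ccc1OCc1ccccc1` — 126 nM
compound 2 `Cc1cc(C(=O)Nc2ccccc2)nn1Cc1cc(Cl)ccc1OCc1ccccc1` — 39.8 nM
compound 3 `Cc1cc(C(=O)Nc2ccc(F)cc2)nn1Cc1cc(Cl)ccc1OCc1ccccc1` — 79.4 nM

All three numbers come from an assay on CHO-K1 cells for displacement of a labelled ligand from prostaglandin E2 receptor EP1 subtype (Homo sapiens); on this read-out lower numbers stand for stronger inhibition and higher numbers for weaker inhibition. Compound 3 sits between the other two, and neither gap is beyond the scatter: a 1.6-fold lower number from compound 1 to compound 3 (0.20 log units; within the scatter) and a 2.0-fold higher number from compound 2 to compound 3 (0.30 log units; within the scatter). For the measured compounds named here, the only step that clears the scatter is a 3.2-fold lower number from compound 1 to compound 2 (0.50 log units; beyond the scatter).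

Compound 4 `Cc1cc(C(=O)Nc2ccccn2)nn1Cc1cc(Cl)ccc1OCc1ccccc1` differs from compound 3 by pyridin-2-yl in place of 4-fluorophenyl on an amide-type nitrogen. Going by the values given here, two measured steps bear on this. First, a 2.0-fold higher number from compound 2 to compound 3 (0.30 log units; within the scatter) shows that taking the fluoro off the aromatic carbon moves the number only within the scatter. Second, a 3.2-fold lower number from compound 1 to compound 2 (0.50 log units; beyond the scatter) and a 1.6-fold lower number from compound 1 to compound 3 (0.20 log units; within the scatter) together show that either aryl group on the amide nitrogen gives a number at or somewhat under that of compound 1. Among the compounds with values here, no measured pair tests a ring nitrogen in that aryl group, so the effect of the pyridin-2-yl itself is unknown. In this assay the step is therefore expected to stay within the scatter, if anything toward a lower number: a 1.3-fold lower number from compound 3 to compound 4 (0.12 log units; within the scatter). Compound 4 is estimated at 60 nM, range 20 nM to 200 nM.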

Compound 4, half-maximal inhibitory concentration: 126 nM
For compound 4 the middle estimate is 2.1-fold (0.32 log units) below the measured one, within the range that was stated.
By their numbers in this assay, from the lowest: compounds 2, 3, 1 and 4 (each within the scatter of the next, the first and the last beyond it).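

In this assay, for the compounds shown here, the ring nitrogen in the aryl group on the amide-type nitrogen can now be read: pyridin-2-yl in place of phenyl gives a 3.2-fold higher number from compound 2 to compound 4 (0.50 log units; beyond the scatter), the only new step beyond the scatter. Pyridin-2-yl in place of 4-fluorophenyl gives a 1.6-fold higher number from compound 3 to compound 4 (0.20 log units; within the scatter), and in place of the amide hydrogen it gives no change at the digits printed from compound 1 to compound 4 (within the scatter), so an aromatic ring on this nitrogen does not by itself move the number clear of compound 1; of the three aryl amides, only compound 2 does so. No measurement shown gives a reason for the step from phenyl to pyridin-2-yl.

On these data alone, what a carboxylic acid on the phenyl ring of compound 2, or an amine or a longer chain on the amide-type nitrogen, would do remains open. As far as these compounds go, the rest of the shared core is constant across these compounds, so whether these steps hold with other groups there is also open.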